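Replacing the 3-chlorophenyl group of compound 1

A few compounds are considered here, and "the series" means these few. Any claim that something is new, unique, unknown or untested is made for them only; others in the source may bear on it.

In an ADME assay on microsomes from liver (Mus musculus) for metabolic stability (a lower number here means that the compound disappears faster, a higher number that the compound lasts longer), compound 1 `NS(=O)(=O)CC(=O)NCCSc1nonc1/C(=N/O)Nc1cccc(Cl)c1` gives 1.26 h, the highest of three numbers and beyond the scatter from the other two. Compound 2 `O=C(NCCSc1nonc1/C(=N/O)Nc1ccc(F)c(C(F)F)c1)C1CS(=O)(=O)C1` gives 0.245 h, and compound 3 `N#CCC(=O)NCCSc1nonc1/C(=N/O)Nc1ccc(F)c(C(F)F)c1` gives 0.278 h. Compound 4 `N#Cc1cc(N/C(=N\O)c2nonc2SCCNC(=O)CS(N)(=O)=O)ccc1F` has yet to be measured. It differs from compound 1 by 3-cyano-4-fluorophenyl in place of 3-chlorophenyl on an amine nitrogen. Within the data shown here, the only measured step, a 1.1-fold higher number from compound 2 to compound 3 (0.05 log units; within the scatter), lies within the scatter and concerns the group on a carbonyl carbon, not this one. Among the measured compounds shown here, no measured step isolates the present change, and the expectation rests mainly on compound 1 at 1.26 h. The expected step, a 1.4-fold lower number from compound 1 to compound 4 (0.15 log units; within the scatter), stays within the scatter. Compound 4 is expected at about 0.9 h, with an estimated range from 0.35 h to 2 h.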

Compound 4, half-life: 2.38 h
Estimate against measurement, compound 4: 2.6-fold (0.42 log units) below; the whole stated range lies below it.
By their numbers in this assay, from the lowest: compounds 2 and 3 (each within the scatter of the next); then compounds 1 and 4 (each within the scatter of the next).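

Among these compounds, the first measured step at the aryl group on the amine nitrogen, 3-cyano-4-fluorophenyl in place of 3-chlorophenyl, reads in this assay as a 1.9-fold higher number from compound 1 to compound 4 (0.28 log units; within the scatter). With the rest of compound 1 held constant, the two aryl groups cannot be told apart, so this larger group carries no measurable penalty here. Nothing available explains this result.

From the compounds shown here alone, it remains open whether 3-cyanophenyl or 4-fluorophenyl alone would read the same. A methoxy group or a bromine atom on the phenyl ring also remains untested in the compounds shown.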